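A few compounds are considered here, and "the series" means these few. Any claim that something is new, unique, unknown or untested is made for them only; others in the source may bear on it.

Of the compounds shown here, three sharing one core have been measured. In a functional assay on MGC-803 cells (Homo sapiens) for inhibition, read by sulforhodamine B assay (on this read-out higher numbers stand for weaker inhibition and lower numbers for stronger inhibition), compound 1 `O=C1C=C(Nc2ccccc2F)C(=O)c2c1nc1n2[C@H]2OC[C@@H](O)[C@H]2OC1` gives 2080 nM, compound 2 `CCc1ccc(NC2=CC(=O)c3nc4n(c3C2=O)[C@H]2OC[C@@H](O)[C@H]2OC4)cc1` gives 1290 nM and compound 3 `COc1ccc(NC2=CC(=O)c3nc4n(c3C2=O)[C@H]2OC[C@@H](O)[C@H]2OC4)cc1` gives 1680 nM, so compound 3 lies within the scatter of both others. Compound 4 `Cc1ccc(NC2=CC(=O)c3nc4n(c3C2=O)[C@H]2OC[C@@H](O)[C@H]2OC4)cc1` carries methyl in place of methoxy on an aromatic carbon, para to a large group (methyl in place of methoxy on an aromatic carbon). Within the data shown here, the nearest precedent is the exchange of ethyl and methoxy at that place, a 1.3-fold higher number from compound 2 to compound 3 (0.11 log units; within the scatter). The two changes of the aromatic ring's substitution, a 1.6-fold lower number from compound 1 to compound 2 (0.21 log units; within the scatter) and a 1.2-fold lower number from compound 1 to compound 3 (0.09 log units; within the scatter), are equally small. No shift beyond the scatter is therefore expected in this assay, and the expected change is a 1.1-fold lower number from compound 3 to compound 4 (0.05 log units; within the scatter). Compound 4 is estimated at 1500 nM, with an expected range of 800 nM to 2800 nM.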

Compound 4, half-maximal inhibitory concentration: 1420 nM
For compound 4 the middle estimate is 1.1-fold (0.02 log units) above the measured one, within the range that was stated.
By their numbers in this assay, from the lowest: compounds 2, 4, 3 and 1 (each within the scatter of the next).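

With methyl, the series in this assay gains a third group on this aromatic carbon, para to a large group, and methyl stays within the scatter of both methoxy (a 1.2-fold lower number from compound 3 to compound 4 (0.07 log units; within the scatter)) and ethyl (a 1.1-fold higher number from compound 2 to compound 4 (0.04 log units; within the scatter)). The 4-methylphenyl of compound 4 also stays within the scatter of the 2-fluorophenyl of compound 1 (a 1.5-fold lower number from compound 1 to compound 4 (0.17 log units; within the scatter)). Nothing available explains why these exchanges leave the number so little changed. From the compounds shown here alone, whether an amine, a carboxylic acid or a longer chain at this place would shift the number beyond the scatter remains open.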